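The source may report more compounds than this note shows. Statements on the series, on what has been measured and on what is new or still open speak of the compounds shown alone.

In an ADME assay on L6 cells (Rattus norvegicus) for cytotoxicity, read by resazurin assay, with a stated time of 70 h (a lower number here means a stronger inhibitor, a higher number a weaker inhibitor), three compounds have been measured so far:

compound 1, `COc1cc(NC(C)CCCNC(=O)/C=C/c2ccccc2)c2ncccc2c1`: 7.2 ug/mL
compound 2, `COc1cc(NC(C)CCCNC(=O)/C=C/c2ccc(OC)c(OC)c2)c2ncccc2c1`: a limit of the assay, > 100 ug/mL
compound 3, `COc1cc(NC(C)CCCNC(=O)/C=C/c2ccc(C(F)(F)F)cc2)c2ncccc2c1`: 73.1 ug/mL

Compound 1 gives the lowest of the two numbers; its nearest neighbour is compound 3, with a 10-fold higher number from compound 1 to compound 3 (1.01 log units; beyond the scatter). Compound 2 sits at the limit of > 100 ug/mL in this assay, at which 1 of the 3 values shown sits, so only a lower bound is known for it, and the step of an at least 13-fold higher number from compound 1 to compound 2 (1.14 log units; beyond the scatter) is itself a bound. Compound 4, `COc1cc(NC(C)CCCNC(=O)Nc2cccc(O)c2)c2ncccc2c1`, has not yet been measured. It differs from compound 1 in one place: (3-hydroxyphenyl)amino in place of 2-phenylethenyl on a carbonyl carbon. Both measured steps that alter the group attached to the carbonyl of compound 1 raise the number by a large margin, as seen in the steps to compound 2 and compound 3, and compound 4 changes that same part of the molecule more deeply. On this basis compound 4 is expected to show a rise in this assay of roughly a 5.6-fold higher number from compound 1 to compound 4 (0.74 log units; beyond the scatter). Compound 4 is therefore estimated at 40 ug/mL, within a range from 10 ug/mL to 100 ug/mL.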

Compound 4, half-maximal inhibitory concentration: 38 ug/mL
Compound 4: the middle estimate sits 1.1-fold (0.02 log units) above what was measured; measured number inside the range.
By their numbers in this assay, from the lowest: compound 1; then compounds 4 and 3 (each within the scatter of the next). At a limit, above all of these: compound 2.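

Going by these compounds alone, the change from compound 1 to compound 4 is the first to replace the whole 2-phenylethenyl group on the carbonyl carbon rather than add to its ring, and in this assay it gives a 5.3-fold higher number from compound 1 to compound 4 (0.72 log units; beyond the scatter). Within the data shown here, the double bond outside aromatic rings is gone and a six-membered aromatic ring of carbon only remains, so a higher number is no longer seen only with groups added to the phenyl ring. Compound 1 still has the lowest number of the series, and nothing measured here accounts for the rise.

The step to compound 4 changes the double bond, the amino nitrogen and the hydroxyl together, and the compounds shown do not separate them. A plain phenylamino group or a saturated 2-phenylethyl chain on the carbonyl carbon would begin to do so.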